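The source may hold more compounds than are shown below. What is called first, only, known or untested is meant among the compounds shown, and "the series" means these compounds.

Measured in a functional assay on A549 cells (Homo sapiens) for cytotoxicity, with a stated time of 48 h; a higher number here means a weaker inhibitor, a lower number a stronger inhibitor:

- compound 1 `C[S+]([O-])/C=C/c1cc(=O)c2cc(F)ccc2o1`: 2100 nM
- compound 2 `CC(C)CCOc1ccc2oc(/C=C/[S+](C)[O-])cc(=O)c2c1`: 1000 nM
- compound 3 `C[S+]([O-])/C=C/c1cc(=O)c2cc(C#N)ccc2o1`: > 10000 nM, a limit and not a number

Compound 3 is the only one of the three that gives no number, and its entry is the limit of > 10000 nM in this assay, at which 1 of the 3 values shown sits. Within the data shown here, the next compound, compound 4 `CC(C)C(=O)Oc1ccc2oc(/C=C/[S+](C)[O-])cc(=O)c2c1`, shares the core of compound 3, and only one group differs. The (isopropylcarbonyl)oxy takes the place of cyano on an aromatic carbon, para to a fused ring: (isopropylcarbonyl)oxy in place of cyano on an aromatic carbon. Two measured steps change the same carbon and end at cyano. The first is an at least 4.7-fold higher number from compound 1 to compound 3 (0.67 log units; beyond the scatter), and the second is an at least 10-fold higher number from compound 2 to compound 3 (1.00 log units; beyond the scatter). A third step, a 2.1-fold lower number from compound 1 to compound 2 (0.32 log units; beyond the scatter), shows that the fluoro and isopentyloxy compounds lie much closer together. Compound 3 is therefore the outlier among the three, though three compounds set no general pattern. Like the isopentyloxy of compound 2 at 1000 nM, the entering group is joined to the ring through oxygen, but it is an ester and no measured compound carries one. A lower number is therefore expected, landing near the fluoro and isopentyloxy compounds rather than at the limit. The expected change is an at least 4.0-fold lower number from compound 3 to compound 4 (0.60 log units; beyond the scatter). For compound 4 the estimate in this assay is 2500 nM, with an expected range from 800 nM to 8000 nM.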

Compound 4, half-maximal inhibitory concentration: 2400 nM
For compound 4 the middle estimate is 1.0-fold (0.02 log units) above the measured one, within the range that was stated.
By their numbers in this assay, from the lowest: compound 2; then compounds 1 and 4 (each within the scatter of the next). At a limit, above all of these: compound 3.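

In this assay the change to (isopropylcarbonyl)oxy on this aromatic carbon gives an at least 4.1-fold lower number from compound 3 to compound 4 (0.61 log units; beyond the scatter) and brings the series back from the limit to a measured number, so the weak result of compound 3 is tied to cyano and not to the shared core. The ester also separates two groups joined to the ring through the same oxygen, since there is a 2.4-fold higher number from compound 2 to compound 4 (0.38 log units; beyond the scatter) when isopropylcarbonyl replaces isopentyl, which shows that what is attached to that oxygen can shift the number and not only the atom on the ring. Fluoro and the ester, by contrast, cannot be told apart, with a 1.1-fold higher number from compound 1 to compound 4 (0.06 log units; within the scatter), so among the four compounds cyano alone goes against a group of values that stay close together.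

Going by these compounds, compound 3 remains a limit and not a number, so the true size of every step to or from cyano stays open: the limit of > 10000 nM in this assay, at which 1 of the 4 values shown sits. Also open, on these data alone, is whether an amine, a carboxylic acid or a longer acyl chain on this carbon would fall with the other compounds or would behave like the nitrile.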